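A few compounds are considered here, and "the series" means these few. Any claim that something is new, unique, unknown or untested is made for them only; others in the source may bear on it.

Compound 1 `O=C1C=CC(OCC(F)(F)F)N1c1ccc(C(F)(F)F)cc1` in a functional assay on K562 cells (Homo sapiens) for inhibition (a lower number here means a stronger inhibitor, a higher number a weaker inhibitor), gives 13100 nM. Compound 2 `O=C1C=CC(OCC(F)(F)F)N1c1ccc([N+](=O)[O-])cc1` in this assay gives 1530 nM.

Within the data shown here, compound 2 thus stands at the lower of the two numbers, and the only measured step, an 8.6-fold lower number from compound 1 to compound 2 (0.93 log units; beyond the scatter), changed the same position. Compound 3 `COC(=O)c1ccc(N2C(=O)C=CC2OCC(F)(F)F)cc1` carries the change (methoxycarbonyl in place of nitro on an aromatic carbon). Among the measured compounds shown here, that one step shows the position matters, but no measured pair speaks to methoxycarbonyl itself, so the direction is uncertain. A step of a 2.3-fold higher number from compound 2 to compound 3 (0.36 log units; beyond the scatter) toward a somewhat higher number is expected. Compound 3 is estimated at 3500 nM, within 900 nM to 14000 nM.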

Compound 3, half-maximal inhibitory concentration: 14700 nM
For compound 3 the middle estimate is 4.2-fold (0.62 log units) below the measured one; the whole stated range lies below it.
By their numbers in this assay, from the lowest: compound 2; then compounds 1 and 3 (each within the scatter of the next).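

Replacing nitro with methoxycarbonyl in this assay gives a 9.6-fold higher number from compound 2 to compound 3 (0.98 log units; beyond the scatter) and so shows that the low number of compound 2 does not carry over to this replacement. Methoxycarbonyl and trifluoromethyl are not separated at this position, with a 1.1-fold higher number from compound 1 to compound 3 (0.05 log units; within the scatter) and thus nitro alone stands apart among the three groups. Nothing available accounts for this result.

As far as these compounds go, whether an amine, a carboxylic acid or a nitrile at this position would give a number as low as that of compound 2 remains open. Also open, from the compounds shown here alone, is whether nitro would keep its lower number on a changed core.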